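A few compounds are considered here, and "the series" means these few. Any claim that something is new, unique, unknown or untested is made for them only; others in the source may bear on it.

Within the data shown here, in a functional assay on A2780 cells (Homo sapiens) for inhibition, read by sulforhodamine B assay, with a stated time of 72 h (on this read-out higher numbers stand for weaker inhibition and lower numbers for stronger inhibition), compound 2 (`O=C(NCc1ccc(S(=O)(=O)c2cccc(C(F)(F)F)c2)cc1)c1cc2ccncc2o1`) gives 3 nM, the lowest number of the three measured so far. Compound 1 (`O=C(NCc1ccc(S(=O)(=O)c2ccccc2)cc1)c1ccc2nccn2c1`) gives 13 nM, and compound 3 (`O=C(NCc1ccc(S(=O)(=O)N2CCCCC2)cc1)c1cc2ccncc2o1`) gives 29 nM. Compound 4 (`O=C(NCc1ccc(S(=O)(=O)c2cccc(C(F)(F)F)c2)cc1)c1ccc2nccn2c1`) remains unmeasured. Its change from compound 2 is a group of 9 heavy atoms (7 carbon, 2 nitrogen; one five-membered aromatic ring with 2 hetero atoms, one six-membered aromatic ring with 1 hetero atom) in place of a group of 9 heavy atoms (7 carbon, 1 nitrogen, 1 oxygen; one five-membered aromatic ring with 1 hetero atom, one six-membered aromatic ring with 1 hetero atom), on a carbonyl carbon.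

Among the measured compounds shown here, the only measured single-place step, a 9.7-fold higher number from compound 2 to compound 3 (0.99 log units; beyond the scatter), lies on a sulfonyl sulfur. It does not test the carbonyl side and shows only how far the series has moved at another place. Compound 1 is the closer guide, since it already carries the entering group, but it lacks the trifluoromethyl group and gives 13 nM. Compound 1 and compound 2 differ in more than one place, so the data do not show how much of their gap belongs to the carbonyl side.

A modest step to a higher number is therefore expected in this assay, estimated as a 2.3-fold higher number from compound 2 to compound 4 (0.37 log units; beyond the scatter). For compound 4 the estimated value is 7 nM, with an expected range of 2 nM to 20 nM.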

Compound 4, half-maximal inhibitory concentration: 2 nM
Estimate against measurement, compound 4: 3.5-fold (0.54 log units) above; low and high end bracket the measured number.
By their numbers in this assay, from the lowest: compounds 4 and 2 (each within the scatter of the next); then compound 1; then compound 3.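

With the trifluoromethyl group held constant, the exchange on the carbonyl carbon in this assay gives a 1.5-fold lower number from compound 2 to compound 4 (0.18 log units; within the scatter), so the two groups are not separated at this position in this setting. With the entering group held constant, trifluoromethyl in place of hydrogen on an aromatic carbon gives a 6.5-fold lower number from compound 1 to compound 4 (0.81 log units; beyond the scatter), which assigns the gap between these two compounds to that single change. No measurement on hand accounts for either step.

On these data alone, whether the trifluoromethyl step carries over to the carbonyl-side group of compound 2 stays open, as does the outcome of a chlorine or methoxy group in place of trifluoromethyl. Also open, as far as these compounds go, is whether the step to piperidin-1-yl on the sulfonyl sulfur holds with the group that compound 4 carries on its carbonyl carbon.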